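A methoxy group added one bond further out

This account rests on a few compounds, and the source may have more. Where it says the series, first, only, none or still open, it means among the compounds named here.

In a functional assay on HL-60 cells (Homo sapiens) for cytotoxicity, read by WST assay, with a stated time of 48 h (on this read-out higher numbers stand for weaker inhibition and lower numbers for stronger inhibition), compound 2 `COc1cc(C(c2ccc(O)c(OC)c2)[C@H](C)C(C)C)ccc1O` gives 17000 nM, the lower of the two numbers reported; the nearest is compound 1 `COC[C@H](C(C)C)C(c1ccc(O)c(OC)c1)c1ccc(O)c(OC)c1`, which gives 72000 nM in this assay. Compound 3 `COc1ccc(C(c2ccc(OC)c(OC)c2)[C@@H](C)[C@H](C)CO)cc1OC` reaches only a limit in this assay, > 100000 nM. One of the three values thus sits at the limit of > 100000 nM in this assay, at which 1 of the 3 values shown sits.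

Compound 4 `COC[C@H](C)[C@@H](C)C(c1ccc(O)c(OC)c1)c1ccc(O)c(OC)c1` has not yet been measured. It differs from compound 2 by methoxy in place of hydrogen on a saturated chain carbon, four bonds along the chain from two aromatic carbons. Going by the values given here, the one measured step that bears on this change is a 4.2-fold lower number from compound 1 to compound 2 (0.63 log units; beyond the scatter), where the same group was removed from a carbon three bonds along the chain from the aromatic carbons. Read backwards, that step suggests that putting a methoxy group back onto the chain raises the number. In compound 4 the group sits four bonds along the chain, so the step from compound 2 is expected to be of similar or somewhat smaller size, upward: a 2.6-fold higher number from compound 2 to compound 4 (0.42 log units; beyond the scatter). Compound 4 is therefore estimated at 45000 nM, with a likely range from 18000 nM to 100000 nM.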

Compound 4, half-maximal inhibitory concentration: 68000 nM
Estimate against measurement, compound 4: 1.5-fold (0.18 log units) below; the range from low to high includes it.
By their numbers in this assay, from the lowest: compound 2; then compounds 4 and 1 (each within the scatter of the next). At a limit, above all of these: compound 3.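

Moving the methoxy group one bond further out did not remove the penalty: in this assay, adding it four bonds along the chain from two aromatic carbons gives a 4.0-fold higher number from compound 2 to compound 4 (0.60 log units; beyond the scatter) on its own, with no other part of the structure changed. The two placements cannot be told apart, since 2-(methoxymethyl)-1-methylpropyl in place of 1-(methoxymethyl)-2-methylpropyl gives a 1.1-fold lower number from compound 1 to compound 4 (0.02 log units; within the scatter), so among compounds 1, 2 and 4 the number tracks whether the chain carries the methoxy group, not which of these two carbons holds it. Nothing shown here accounts for why the methoxy group has this effect.

On these data alone, whether an amine, a carboxylic acid or a longer chain at this carbon would behave the same way stays open. Compound 3 gives only a limit (> 100000 nM) and offers no single-place comparison.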